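The source may hold more compounds than are shown below. What is called first, only, known or untested is meant among the compounds shown, and "the series" means these compounds.

All values here come from an ADME assay on the whole organism (strain CD-1) for metabolic stability, with Mus musculus as the target, at a dose of 3 mg/kg by the intravenous route (a lower number here means that the compound disappears faster, a higher number that the compound lasts longer), and concern the chain that ends in the acid. Compound 1 `CC(CCCCOc1ccccc1CN(C)C(=O)c1ccc(-c2ccco2)cc1)C(=O)O` stands at 2.8 h, compound 2 `CN(Cc1ccccc1OCCC/C=C/C(=O)O)C(=O)c1ccc(-c2ccco2)cc1` at 1.9 h and compound 3 `C/C(=C\CCCOc1ccccc1CN(C)C(=O)c1ccc(-c2ccco2)cc1)C(=O)O` at 1.2 h. Compound 3 is therefore separated from the other two by different margins (a 1.6-fold lower number from compound 2 to compound 3 (0.20 log units; within the scatter)) and (a 2.3-fold lower number from compound 1 to compound 3 (0.37 log units; beyond the scatter)).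

Compared with compound 3, compound 4 `C/C(=C\C(=O)O)CCCOc1ccccc1CN(C)C(=O)c1ccc(-c2ccco2)cc1` has the same atoms joined differently (2-carboxy-1-methylethenyl in place of 2-carboxyprop-1-en-1-yl on a saturated chain carbon, three bonds along the chain from an oxygen on an aromatic ring), with 2-carboxy-1-methylethenyl in place of 2-carboxyprop-1-en-1-yl on a saturated chain carbon, three bonds along the chain from an oxygen on an aromatic ring. Within the data shown here, no measured compound carries this arrangement. Compound 4 keeps a chain double bond, as compound 2 and compound 3 do, so the closest evidence is the step between those two (a 1.6-fold lower number from compound 2 to compound 3 (0.20 log units; within the scatter)). The step from the saturated chain (a 1.5-fold lower number from compound 1 to compound 2 (0.17 log units; within the scatter)) is also within the scatter, and the modest one (a 2.3-fold lower number from compound 1 to compound 3 (0.37 log units; beyond the scatter)) starts from a chain that compound 4 does not share. The expected step (a 1.3-fold higher number from compound 3 to compound 4 (0.10 log units; within the scatter)) is therefore none beyond the scatter. Compound 4 is estimated at 1.5 h within an expected range (0.8 h to 2.8 h).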

Compound 4, half-life: 1.6 h
The estimate for compound 4 lay 1.1-fold (0.03 log units) below the measured number; the measured number falls inside the stated range.
By their numbers in this assay, from the lowest: compounds 3, 4, 2 and 1 (each within the scatter of the next, the first and the last beyond it).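

In this assay, 2-carboxy-1-methylethenyl in place of 2-carboxyprop-1-en-1-yl gives a 1.3-fold higher number from compound 3 to compound 4 (0.12 log units; within the scatter) and so does not separate these two ways of joining the same atoms on the chain. Against 2-carboxyethenyl the new group gives a 1.2-fold lower number from compound 2 to compound 4 (0.07 log units; within the scatter) and against 2-carboxypropyl it gives a 1.8-fold lower number from compound 1 to compound 4 (0.24 log units; within the scatter) and thus, unlike compound 3, compound 4 lies within the scatter of every other compound shown. Nothing available bears on the cause of these numbers.

The compounds shown leave open how the other geometric isomer of 2-carboxy-1-methylethenyl would read in this assay and whether a saturated chain with the methyl group on that same carbon would match compound 1. They also leave open what a tetrazole in place of the carboxylic acid, or a longer chain, would do at this position.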